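This account rests on a few compounds, and the source may have more. Where it says the series, first, only, none or still open, it means among the compounds named here.

Measured compounds in a functional assay on MDA-MB-231 cells (Homo sapiens) for inhibition, read by sulforhodamine B assay; a lower number here means a stronger inhibitor of growth, a higher number a weaker inhibitor of growth:
compound 1, `O=C(CCC1=CCCN(CCCCc2ccc(-c3ccccc3)cc2)C1=O)NO`: 1280 nM
compound 2, `COc1ccc(CN2CCC=C(CCC(=O)NO)C2=O)cc1`: 3860 nM
compound 3, `COc1cccc(CN2CCC=C(CCC(=O)NO)C2=O)c1`: 3920 nM

Compound 2 stands second highest among the three numbers in this assay. Its nearest neighbour is compound 3, whose number lies within the scatter of that of compound 2, so the two cannot be set in order. The furthest is compound 1, whose number is beyond the scatter lower than that of compound 2, so compound 1 is the stronger growth inhibitor of the two.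

Compound 4, `O=C(CCC1=CCCN(Cc2ccc(Br)cc2)C1=O)NO`, has not yet been measured. It differs from compound 2 in one place: bromo in place of methoxy on an aromatic carbon

Going by the values given here, no step between two measured compounds shows how such a change plays out in this assay, so there is nothing directly to lean on. Among the compounds with values here, the two measured methoxy-bearing compounds, compound 2 and compound 3, sit close together, and the only compound with a clearly lower number, compound 1, carries a quite different chain. The author therefore expects the step from compound 2 to compound 4 to be small, if anything a modest move toward a lower number, and likely within the scatter: a 1.3-fold lower number from compound 2 to compound 4 (0.11 log units; within the scatter). For compound 4 the estimated value in this assay is 3000 nM, with a range from 1200 nM to 7500 nM.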

Compound 4, concentration for 50% growth inhibition: 1630 nM
Estimate against measurement, compound 4: 1.8-fold (0.26 log units) above, within the range that was stated.
By their numbers in this assay, from the lowest: compounds 1 and 4 (each within the scatter of the next); then compounds 2 and 3 (each within the scatter of the next).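

In this assay, putting bromo in place of methoxy on the aromatic carbon para to a large group gives a 2.4-fold lower number from compound 2 to compound 4 (0.37 log units; beyond the scatter) and so makes compound 4 the stronger growth inhibitor of the pair, though the step is modest. Going by these compounds alone, the earlier compounds offered no step between measured neighbours, and this one is the first to show that the group held at this position can move the number beyond the scatter while the rest of the structure stays the same. Nothing measured here accounts for the difference between methoxy and bromo, so the reason for this step remains unknown.

The compounds shown leave open whether the lower number is particular to bromo or would also appear with other groups on this aromatic carbon, such as chloro, a nitrile, an amine or a carboxylic acid. They also leave open whether the same exchange would give a step of similar size in compound 3, which carries its methoxy at a different place on the ring.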